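Methoxy for fluoro on the phenyl ring of compound 3

The compounds below may be only part of what the source reports. "The series", "measured", "known", "first", "only" and "open" are said of these compounds alone.

Compound 3 `Cc1cc(NC(=O)Cn2nnc(-c3cccc(F)c3)n2)n(C2CCCCC2)n1` is the compound from which this step sets out. In an assay on HEK293 cells for activation of Kir3.1/Kir3.2 (Homo sapiens), read by thallium flux (on this read-out higher numbers stand for larger maximal responses and lower numbers for smaller maximal responses), compound 3 gives 96%, the highest of the two numbers shown. The nearest number belongs to compound 2 `Cc1cc(NC(=O)Cn2nnc(-c3ccccc3)n2)n(C2CCS(=O)(=O)C2)n1`, which gives 93% in this assay, a gap that lies within the scatter, so no order between compound 2 and compound 3 can be read. Compound 1 `CCC(C)n1nc(C)cc1NC(=O)Cn1nnc(-c2ccccc2)n1` gives only a limit in this assay, reported as > 69%. Among the compounds with values here, the one step between measured compounds, a step that the limit leaves unreadable from compound 1 to compound 2, cannot be sized because of the limit of > 69% in this assay, at which 1 of the 3 values shown sits.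

Compound 4 `COc1cccc(-c2nnn(CC(=O)Nc3cc(C)nn3C3CCCCC3)n2)c1` differs from compound 3 in one place: methoxy in place of fluoro on an aromatic carbon. Within the data shown here, no measured step touches the phenyl ring, so none bears on this change, and the single step that is known is unreadable. Both readable numbers sit high and close to each other, which leaves no ground for expecting a shift beyond the scatter. Compound 4 is therefore expected to give about 90% in this assay, between 75% and 102%. The step of a number 6 percentage points lower from compound 3 to compound 4 (within the scatter) is estimated to stay within the scatter.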

Compound 4, largest response reached (Emax), in percent of the reference or control that the assay uses: 76%
Compound 4: the middle estimate sits 14 percentage points above what was measured, within the range that was stated.
By their numbers in this assay, from the lowest: compound 4; then compounds 2 and 3 (each within the scatter of the next).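

Going from 3-fluorophenyl to 3-methoxyphenyl, at a place on an aromatic carbon meta to a large group, brings in this assay a number 20 percentage points lower from compound 3 to compound 4 (beyond the scatter). Within the data shown here, the phenyl ring had not been touched by any earlier step, and the only earlier step cannot be read, so this is the first readable evidence that a single change can alter the maximal response. With the rest of the molecule unchanged, the exchange of fluoro for methoxy on this ring is enough to separate the two compounds, although the data shown give no measured property that accounts for the drop.

On these data alone, what an unsubstituted phenyl, or a chloro, hydroxy or ethoxy group at this place, would give on the core of compound 3 remains open, so the pair alone cannot tell whether losing fluoro or gaining methoxy matters more. Also open, as far as these compounds go, is whether methoxy for fluoro would bring a step of similar size with the sec-butyl of compound 1 or the 1,1-dioxothiolan-3-yl of compound 2 on the aromatic nitrogen.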